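The source may report more compounds than this note shows. Statements on the series, on what has been measured and on what is new or still open speak of the compounds shown alone.

Of the compounds shown here, three share one core and have been measured in a physicochemical assay for lipophilicity; a higher number here means a more lipophilic compound, a lower number a more polar compound. Compound 1, `C[n+]1ccn(COCCC[Si](C)(C)C)c1/C=N/O`, gives 0.43. Compound 2, `C[n+]1ccn(CCCCC#N)c1/C=N/O`, gives -2.8. Compound 3, `C[n+]1ccn(CCOCCF)c1/C=N/O`, gives -2.62, which is the second highest of the three numbers; the step of a number 0.18 log units higher from compound 2 to compound 3 (within the scatter) is small, while compound 1 sits far above it. Compound 4, `C[n+]1ccn(COCCCBr)c1/C=N/O`, is not yet measured; the change is 3-bromopropoxy in place of (2-fluoroethoxy)methyl on a saturated chain carbon bound to an aromatic nitrogen. Among the measured compounds shown here, only the step of a number 0.18 log units higher from compound 2 to compound 3 (within the scatter) resembles this change, and it stayed within the scatter, so the sideways exchange of one chain for another carries little weight on its own. Compound 4 is nevertheless expected to come out higher than compound 3, by an estimated a number 1.02 log units higher from compound 3 to compound 4 (beyond the scatter), giving an estimated value of -1.6 with a range from -2.3 to -0.9.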

Compound 4, distribution coefficient: -1.76
The estimate for compound 4 lay 0.16 log units above the measured number, and the stated range covers the measured number.
By their numbers in this assay, from the lowest: compounds 2 and 3 (each within the scatter of the next); then compound 4; then compound 1.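

In this assay, exchanging one chain for another at this position, on a saturated chain carbon bound to an aromatic nitrogen, can move the number beyond the scatter (a number 0.86 log units higher from compound 3 to compound 4 (beyond the scatter); a number 1.04 log units higher from compound 2 to compound 4 (beyond the scatter)). The 3-bromopropoxy chain still does not reach the silicon-bearing chain (a number 2.19 log units lower from compound 1 to compound 4 (beyond the scatter)). No measured evidence here explains these steps.

Going by these compounds, it remains open whether the bromine or the rest of the changed chain carries the step. On these data alone, how a chlorine-ended chain, a longer chain or an amine would read at this position also remains open.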